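Dichlorophenyl Analogue Expected to Stay Within the Assay Limit

The source may hold more compounds than are shown below. What is called first, only, known or untested is meant among the compounds shown, and "the series" means these compounds.

Three compounds built on one shared core are compared here. Compound 1 `Cc1nc(-c2cccnc2)sc1-c1nnc(Cc2ccccc2)o1` carries a benzyl group on the five-membered ring. In an ADME assay on HCT-116 cells (Homo sapiens) for cytotoxicity, read by MTT assay (a lower number here means that less compound is tolerated, a higher number that more compound is tolerated), compound 1 gives only a limit, > 100 ug/mL. Compound 2 `Cc1nc(-c2cccnc2)sc1-c1nnc(-c2ccc(Br)cc2)o1` carries a 4-bromophenyl group in its place, and in this assay compound 2 likewise gives only a limit, > 100 ug/mL. Compound 3 `Cc1nc(-c2cccnc2)sc1-c1nnc(-c2ccc(Cl)cc2)o1` carries a 4-chlorophenyl group, and in this assay compound 3 again gives only a limit, > 100 ug/mL. All three values sit together at the limit of > 100 ug/mL in this assay, at which 3 of the 3 values shown sit. Because of this the steps a step that the two limits leave unreadable from compound 1 to compound 2, a step that the two limits leave unreadable from compound 1 to compound 3 and a step that the two limits leave unreadable from compound 2 to compound 3 have no readable size, so compound 3 stands at the limit with no measured neighbour that separates from it.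

Compound 4 `Cc1nc(-c2cccnc2)sc1-c1nnc(-c2cccc(Cl)c2Cl)o1` differs from compound 3 by 2,3-dichlorophenyl in place of 4-chlorophenyl on an aromatic carbon. Among the measured compounds shown here, none of the measured steps gives a readable size, so no direction can be drawn from them; the nearest ones, the steps from benzyl to a halogenated phenyl and between the two halogens, all ended at the same limit. Compound 4 is therefore expected to give 100 ug/mL, with a range from 50 ug/mL to 200 ug/mL. The step of a number no higher from compound 3 to compound 4 (the limit leaves the size open) is estimated to show nothing beyond the scatter, most likely ending again at the limit.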

Compound 4, half-maximal cytotoxic concentration: > 100 ug/mL
Compound 4 gave a limit, no number; the forecaster's own chance of this, stated with the estimate: 80%; the middle value sits exactly at the limit.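

Compound 4, like compound 1, compound 2 and compound 3, gives only a limit in this assay, so none of its steps to those compounds can be read: the limit of > 100 ug/mL in this assay, at which 4 of the 4 values shown sit.

The compounds shown leave open whether the benzyl, 4-bromophenyl, 4-chlorophenyl and 2,3-dichlorophenyl groups differ at all in this assay.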